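Swapping the Group on the Ring Nitrogen: Half-Life Outlook

A few compounds are considered here, and "the series" means these few. Any claim that something is new, unique, unknown or untested is made for them only; others in the source may bear on it.

Compound 1 `CC(C)(C)c1cc(NC(=O)[C@@H]2CCCCN2C2CC2)no1` gives 0.183 h in an ADME assay (liver) for metabolic stability, with Liver microsome (Homo sapiens) as the target, read by LC-MS, using microsomes and NADPH, tested at 1 uM; on this read-out higher numbers stand for a longer-lived compound and lower numbers for a shorter-lived compound.
Compound 2 `CC(C)(C)c1cc(NC(=O)[C@@H]2CCCCN2CC2CCOCC2)no1` gives 0.183 h in this assay.

Compound 2 stands level with compound 1: the step of no change at the digits printed from compound 1 to compound 2 (within the scatter) lies within the usual scatter, so exchanging cyclopropyl for (oxan-4-yl)methyl on the ring nitrogen left the half-life unchanged. Compound 3 `CC(C)(C)c1cc(NC(=O)[C@@H]2CCCCN2C(=O)C2CCCCC2)no1` differs from compound 2 in one place: cyclohexylcarbonyl in place of (oxan-4-yl)methyl on an amine nitrogen in a ring. Among the measured compounds shown here, only the step from compound 1 to compound 2 bears on this, and it was flat; yet that step kept the nitrogen as a simple amine, while the entering cyclohexylcarbonyl places a carbonyl on it, a kind of change no measured step covers. No direction can therefore be read from the data, and a wide range is warranted. Compound 3 is expected to give 0.25 h, with a range from 0.1 h to 0.7 h, which means an expected step of a 1.4-fold higher number from compound 2 to compound 3 (0.14 log units; within the scatter) that does not go beyond the scatter.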

Compound 3, half-life: 0.483 h
For compound 3 the middle estimate is 1.9-fold (0.29 log units) below the measured one; low and high end bracket the measured number.
By their numbers in this assay, from the lowest: compounds 1 and 2 (each within the scatter of the next); then compound 3.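

Of the three groups shown on the ring nitrogen, only cyclohexylcarbonyl moves the half-life in this assay beyond the scatter, both against (oxan-4-yl)methyl (a 2.6-fold higher number from compound 2 to compound 3 (0.42 log units; beyond the scatter)) and against cyclopropyl (a 2.6-fold higher number from compound 1 to compound 3 (0.42 log units; beyond the scatter)). The flat step between the two simple amines therefore did not mean that this position is indifferent to what it carries, since a group with a carbonyl on the nitrogen gives a clearly higher number. Nothing at hand explains the longer half-life.

Cyclohexylcarbonyl differs from (oxan-4-yl)methyl both in its carbonyl and in its carbon-only ring, so these compounds cannot separate the two changes. Going by these compounds, a cyclohexylmethyl group would keep the carbon-only ring without the carbonyl and an acetyl group would keep the carbonyl without the ring, and how either would fare on this nitrogen remains open.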